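Butoxy to Butylamino on a Shared Coumarin-Free Core

The compounds below may be only part of what the source reports. "The series", "measured", "known", "first", "only" and "open" are said of these compounds alone.

Three measured compounds share one core and are judged in a functional assay on WiDr cells (Homo sapiens) for inhibition, read by sulforhodamine B assay, with a stated time of 48 h; a higher number here means a weaker inhibitor of growth, a lower number a stronger inhibitor of growth. Compound 1 `CCOC(=[Se])Nc1ccc2c(C)cc(=O)oc2c1` reaches only a limit of the assay, > 100000 nM. Compound 2 `CCCOC(=[Se])Nc1ccc2c(C)cc(=O)oc2c1` gives 42000 nM. Going by the values given here, the single measured step, an at least 2.3-fold lower number from compound 1 to compound 2 (0.37 log units; beyond the scatter), is the only guide to how the chain length matters. Compound 3 `CCCCOC(=[Se])Nc1ccc2c(C)cc(=O)oc2c1` has no number at all, recorded as "nd(insoluble)" (no result reported), so it cannot be placed among these values. Compound 4 `CCCCNC(=[Se])Nc1ccc2c(C)cc(=O)oc2c1` differs from compound 3 by butylamino in place of butoxy on a saturated chain carbon bound to a nitrogen on an aromatic ring. Among the compounds with values here, no measured step swaps an oxygen for a nitrogen in this way, so the expectation rests on compound 2 alone, whose 42000 nM is the only number in hand, and no shift beyond the scatter can be foreseen in either direction. Compound 4 is therefore expected near 30000 nM, between 8000 nM and 150000 nM.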

Compound 4, concentration for 50% growth inhibition: 3800 nM
For compound 4 the middle estimate is 7.9-fold (0.90 log units) above the measured one, and the stated range ends above it.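

Butylamino at this position brings the first large drop in the series, with an 11-fold lower number from compound 2 to compound 4 (1.04 log units; beyond the scatter) and an at least 26-fold lower number from compound 1 to compound 4 (1.42 log units; beyond the scatter) as the two steps. Both steps change the chain as well as the atom that joins it, so they cannot separate the nitrogen from the chain length, and the direct swap from compound 3 cannot be read. The second step starts from compound 1, whose value is a limit and not a number: the limit of > 100000 nM in this assay, at which 1 of the 4 values shown sits.

On these data alone, whether propylamino would match butylamino remains open. So does the effect of a longer chain on the nitrogen, such as hexylamino.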